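Urea series: triazolyl replaces methylpiperazinyl on the benzyl ring

A few compounds are considered here, and "the series" means these few. Any claim that something is new, unique, unknown or untested is made for them only; others in the source may bear on it.

Going by the values given here, in an assay on microsomes from intestine for inhibition of acyl-CoA:cholesterol acyltransferase (Oryctolagus cuniculus) (a lower number here means a stronger inhibitor, a higher number a weaker inhibitor), compound 1 `Cc1cc(C)c(NC(=O)N(Cc2ccc(N3CCN(C)CC3)cc2)C2CCCCCC2)c(C)c1` gives 57 nM, the higher of the two numbers so far; compound 2 `Cc1cc(C)c(NC(=O)N(Cc2cccc(-c3ccn(C)n3)c2)C2CCCCCC2)c(C)c1` gives 42 nM, within the scatter of compound 1. Compound 3 `Cc1cc(C)c(NC(=O)N(Cc2ccc(-n3nccn3)cc2)C2CCCCCC2)c(C)c1` is compound 1 with one change: 2H-1,2,3-triazol-2-yl in place of 4-methylpiperazin-1-yl on an aromatic carbon. Among the compounds with values here, no step between measured compounds covers this change. Compound 2, which also carries a five-membered aromatic ring on its benzyl ring, gives 42 nM, so a similar number is expected for compound 3. The expected step from this change is a 1.1-fold lower number from compound 1 to compound 3 (0.06 log units; within the scatter), not beyond the scatter. In this assay compound 3 is estimated at 50 nM, range 15 nM to 160 nM.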

Compound 3, half-maximal inhibitory concentration: 130 nM
Estimate against measurement, compound 3: 2.6-fold (0.41 log units) below, within the range that was stated.
By their numbers in this assay, from the lowest: compounds 2 and 1 (each within the scatter of the next); then compound 3.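

At the place para to a large group, the position is sensitive to which ring it carries: in this assay, 2H-1,2,3-triazol-2-yl in place of 4-methylpiperazin-1-yl gives a 2.3-fold higher number from compound 1 to compound 3 (0.36 log units; beyond the scatter). The step is modest, so the five-membered aromatic ring is tolerated but does not match the six-membered non-aromatic ring here. Nothing available explains this step.

Open, on these data alone, is whether the loss follows the ring type or the particular ring. A morpholin-4-yl or a pyrazol-1-yl group at this same place would separate the two.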